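Piperazine aryl swap in an A3 binding series

A few compounds are considered here, and "the series" means these few. Any claim that something is new, unique, unknown or untested is made for them only; others in the source may bear on it.

Measured compounds:
compound 1 `Nc1scc(CN2CCN(c3cccc(Cl)c3Cl)CC2)c1C(=O)c1ccc(Cl)cc1` gives 0%
compound 2 `Nc1scc(CN2CCN(C3CCCC3)CC2)c1C(=O)c1ccc(Cl)cc1` gives 3%

Both numbers come from an assay on CHO cells for displacement of a labelled ligand from adenosine receptor A3 (Homo sapiens), read by scintillation counting, with a stated time of 120 min, tested at 10 uM; a lower number here means less inhibition, a higher number more inhibition at the concentration tested (going by the name of the read-out). Within the data shown here, compound 2 and compound 1 sit within the scatter of each other, so neither can be placed above the other; the only step measured, a number 3 percentage points higher from compound 1 to compound 2 (within the scatter), is itself within the scatter.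

Compound 3 `Nc1scc(CN2CCN(c3cccc(F)c3)CC2)c1C(=O)c1ccc(Cl)cc1` is not yet measured. It differs from compound 2 by 3-fluorophenyl in place of cyclopentyl on an amine nitrogen in a ring. Among the measured compounds shown here, the one measured step at this position, from a dichlorinated aromatic ring to a five-membered saturated ring, moved nothing beyond the scatter, and the new group returns to an aromatic ring of the same size class as in compound 1. No change beyond the scatter is therefore expected in this assay. The expected step of no change at the digits printed from compound 2 to compound 3 (within the scatter) is estimated as flat. Compound 3 is expected to give about 3%, with a range from -8% to 14%.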

Compound 3, a percentage reported as inhibition, at one concentration (the size of the read-out at that concentration, not a potency): 4%
For compound 3 the middle estimate is 1 percentage points below the measured one, within the range that was stated.
By their numbers in this assay, from the lowest: compounds 1, 2 and 3 (each within the scatter of the next).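

In this assay the change gives a number 1 percentage points higher from compound 2 to compound 3 (within the scatter), and the replacement of 2,3-dichlorophenyl by 3-fluorophenyl gives a number 4 percentage points higher from compound 1 to compound 3 (within the scatter). This position now holds a chlorinated aromatic ring, a fluorinated aromatic ring and a saturated carbon ring, and the numbers do not separate any of the three, so neither the ring type nor the halogen pattern registers at this concentration. Nothing available explains this flat picture.

Going by these compounds, whether any group on this amine nitrogen can lift the number beyond the scatter stays open, for example a carboxylic acid on a longer chain or a pyridine ring. Also open, on these data alone, is whether the flat picture at this position holds with a different substituent elsewhere on the shared core.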